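This account rests on a few compounds, and the source may have more. Where it says the series, first, only, none or still open, it means among the compounds named here.

Working notes on the series. In an ADME assay on Vero cells (Chlorocebus sabaeus) for cytotoxicity, read by MTT assay, with a stated time of 96 h (a higher number here means that more compound is tolerated, a lower number that less compound is tolerated), compound 1 (`CC(=O)c1ccc2c(c1)nc(-c1ccc(Cl)cc1)n2C1CCCCC1`) gives > 100000 nM, which is a limit of the assay and not a number. For the measured compounds named here, compound 2 (`CC(=O)c1ccc2c(c1)nc(-c1ccc(C(F)(F)F)cc1)n2C1CCCCC1`) gives 35000 nM, the only actual number so far. The standing of compound 2 can be told only against the limit of compound 1. Going by the values given here, the one measured step is an at least 2.8-fold lower number from compound 1 to compound 2 (0.45 log units; beyond the scatter), with trifluoromethyl in place of chloro on an aromatic carbon.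

Compound 3 (`C/C(=N\NC(N)=S)c1ccc2c(c1)nc(-c1ccc(C(F)(F)F)cc1)n2C1CCCCC1`) keeps the trifluoromethyl of compound 2 and gives up the acetyl: a group of 7 heavy atoms (3 carbon, 3 nitrogen, 1 sulfur; no ring) in place of a group of 3 heavy atoms (2 carbon, 1 oxygen; no ring), on an aromatic carbon. The new group stands on an aromatic carbon, meta to a fused ring and para to a fused ring. The measured step from chloro to trifluoromethyl lies elsewhere on the molecule and bears on this change only loosely, as a sign that one substitution can move the number beyond the scatter. Among the compounds with values here, no measured step covers the acetyl position. A modest move to a lower number in this assay is therefore expected, with wide uncertainty. The estimated step is a 2.3-fold lower number from compound 2 to compound 3 (0.37 log units; beyond the scatter). Compound 3 is expected at 15000 nM, with an estimated range of 3000 nM to 60000 nM.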

Compound 3, half-maximal cytotoxic concentration: > 100000 nM
Compound 3 was reported as a limit; the forecaster's own chance of this, stated with the estimate: 10%; middle value at least 6.6-fold (0.82 log units) from the limit.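

For the compounds shown here, the acetyl position, which no earlier step covered, proves able to move the number in this assay: the group of 7 heavy atoms in place of acetyl gives an at least 2.8-fold higher number from compound 2 to compound 3 (0.45 log units; beyond the scatter). Compound 3 gives > 100000 nM, which is a limit and not a number. From the compounds shown here alone, the lower number seen with trifluoromethyl in compound 2 therefore does not hold across a change at this position, and the full size of the step stays unknown because the result sits at the limit: the limit of > 100000 nM in this assay, at which 2 of the 3 values shown sit.

The compounds shown do not separate the parts of the entering group, so it remains open whether its sulfur, its nitrogens or its greater size goes with the higher number, and whether an amine or a carboxylic acid in place of acetyl would move the number in this assay the same way. Going by these compounds, it also remains open whether the change at this position reads the same with chloro in place of trifluoromethyl, since both compounds with chloro or with this group give no actual number to compare.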